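The source may report more compounds than this note shows. Statements on the series, on what has been measured and on what is new or still open speak of the compounds shown alone.

Series notes. Three ureas sharing one core have been measured in a functional assay on NCI-H226 cells (Homo sapiens) for inhibition, read by MTT assay, with a stated time of 48 h, tested at 10 uM; a lower number here means less inhibition, a higher number more inhibition at the concentration tested (going by the name of the read-out). Compound 1 `COc1cc(NC(=O)Nc2cc(Nc3ccc(C)c(C)c3)ncn2)cc(OC)c1` gives 45.3%. Compound 2 `COc1ccc(Nc2cc(NC(=O)Nc3c(Cl)cccc3Cl)ncn2)cc1C` gives 50%, and compound 3 `O=C(Nc1cc(Nc2ccc(F)c(Cl)c2)ncn1)Nc1c(Cl)cccc1Cl` gives 47.3%. Compound 1 stands with the other two: its gap to compound 3 and its gap to compound 2 both fall inside the usual scatter of repeated measurements, so the three numbers are not separable in this assay.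

One single-point step is known. Between compound 2 and compound 3 the aryl group on the nitrogen on the aromatic ring is exchanged, 3-chloro-4-fluorophenyl in place of 4-methoxy-3-methylphenyl, and the read-out moves by a number 2.7 percentage points lower from compound 2 to compound 3 (within the scatter), which is within the scatter.

Compound 4 `COc1cc(NC(=O)Nc2cc(Nc3ccc(Br)cc3OC)ncn2)cc(OC)c1` is not yet measured. It differs from compound 1 in the same position that the known step touches: 4-bromo-2-methoxyphenyl in place of 3,4-dimethylphenyl on a nitrogen on an aromatic ring. For the measured compounds named here, the only comparable step, the exchange on that nitrogen from compound 2 to compound 3, gave no change beyond the scatter, so no movement beyond the scatter is expected here either, and the step from compound 1 to compound 4 is estimated as a number 1.7 percentage points higher from compound 1 to compound 4 (within the scatter). Compound 4 is expected to give 47% in this assay, with a range from 35% to 60%.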

Compound 4, a percentage reported as inhibition, at one concentration (the size of the read-out at that concentration, not a potency): 25.7%
The estimate for compound 4 lay 21.3 percentage points above the measured number, and the stated range ends above it.
By their numbers in this assay, from the lowest: compound 4; then compounds 1, 3 and 2 (each within the scatter of the next).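

The aryl group on the nitrogen on the aromatic ring is not an indifferent position in this assay: with 4-bromo-2-methoxyphenyl in place of 3,4-dimethylphenyl, the read-out shows a number 19.6 percentage points lower from compound 1 to compound 4 (beyond the scatter). The earlier exchange at this position, a number 2.7 percentage points lower from compound 2 to compound 3 (within the scatter), gave no sign of this, so an exchange here can leave the read-out within the scatter or move it beyond, depending on the groups involved and possibly on the group at the other end of the urea, which differs between the two steps. The entering group brings an oxygen, a bromine and one hydrogen-bond acceptor, and no measurement at hand accounts for the lower number.

Going by these compounds, it remains open whether the bromine, the methoxy group or the pair of them goes with this step, which a phenyl group carrying only a 4-bromo or only a 2-methoxy substituent on that nitrogen would help to separate. On these data alone, it is also open whether the same exchange would read alike with the urea partner of compound 2, and how a morpholine or a carboxylic acid on this aryl ring would read.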